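This account rests on a few compounds, and the source may have more. Where it says the series, first, only, none or still open, it means among the compounds named here.

Measured compounds:
compound 1 `CNc1ncccc1C(=O)N/N=C/c1ccccc1`, 22.7%
compound 2 `CNc1ncccc1C(=O)N/N=C/c1cccc(Cl)c1`, 39.6%

Both compounds were tested in a functional assay on the whole organism (strain Wistar) for inhibition, with Rattus norvegicus as the target, read by paw edema, with a stated time of 3 h, at a dose of 10 mg/kg by the intraperitoneal route; a higher number here means more inhibition at the dose given (going by the name of the read-out), a lower number less inhibition. Compound 1 gives 22.7%, which is the lower of the two numbers. Within the data shown here, its only neighbour is compound 2, and the step of a number 16.9 percentage points higher from compound 1 to compound 2 (beyond the scatter) lies beyond the scatter, so the inhibition in this assay is higher for compound 2 than for compound 1. That step comes from a chloro in place of hydrogen on an aromatic carbon.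

The next compound, compound 3 `CNc1ncccc1C(=O)N/N=C/c1cccnc1`, differs from compound 1 in a different way: pyridin-3-yl in place of phenyl on a carbon with a double bond to nitrogen. Among the measured compounds shown here, no measured step shows this kind of change. For the measured compounds named here, the single step at hand swaps a hydrogen for a chloro and says nothing about exchanging one ring for another, so there is no measured basis for predicting a shift in either direction. With nothing to lean on, the expectation is a number close to that of compound 1. The step of a number 2.3 percentage points higher from compound 1 to compound 3 (within the scatter) is expected to stay within the scatter. Compound 3 is therefore estimated at 25% in this assay, with a range from 10% to 42%.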

Compound 3, a percentage reported as inhibition, in the whole organism at one dose (the size of the read-out at that dose, not a potency): 27.7%
For compound 3 the middle estimate is 2.7 percentage points below the measured one; low and high end bracket the measured number.
By their numbers in this assay, from the lowest: compounds 1 and 3 (each within the scatter of the next); then compound 2.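

In this assay, pyridin-3-yl in place of phenyl on the carbon with a double bond to nitrogen gives a number 5 percentage points higher from compound 1 to compound 3 (within the scatter) and so cannot be told apart from no change at all. Until now this part of the molecule had been probed only by adding a chloro to the phenyl ring, whereas this result shows that a ring with one carbon exchanged for nitrogen, and with one hydrogen-bond acceptor where phenyl has none, can stand here without a shift beyond the scatter. This holds for this single pair at a single dose, and nothing measured here speaks to why the two rings give such similar numbers.

The compounds shown leave open whether the ring nitrogen can sit elsewhere, as in pyridin-2-yl or pyridin-4-yl, and whether a saturated ring such as cyclohexyl would serve in the same place. They also leave open whether a chloro on the pyridin-3-yl ring would have the effect it has on phenyl, or whether an amine or a carboxylic acid on either ring would change the inhibition.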